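The compounds below may be only part of what the source reports. "The series", "measured", "known", "first", "only" and "open" are said of these compounds alone.

Working notes on the series. Among the measured compounds shown here, in an assay on Jurkat cells for displacement of a labelled ligand from C-X-C chemokine receptor type 4 (Homo sapiens), tested at 10 uM (a higher number here means more inhibition at the concentration tested (going by the name of the read-out), a lower number less inhibition), compound 3 `C[C@H](NC(=O)[C@H](CCCNC(=N)N)NC(=O)c1ccc(CN(Cc2ccccn2)C(=O)c2ccc(F)cc2)cc1)c1cccc2ccccc12` gives 36%, the highest of the three numbers so far. Compound 2 `C[C@H](NC(=O)[C@H](CCCNC(=N)N)NC(=O)c1ccc(CN(Cc2ccncc2)Cc2ccc(F)cc2)cc1)c1cccc2ccccc12` gives 16% in this assay, and compound 1 `C[C@@H](NC(=O)[C@H](CCCNC(=N)N)NC(=O)c1ccc(CN(Cc2ccccn2)C(=O)c2ccc(F)cc2)cc1)c1cccc2ccccc12` gives 3%. Compound 1 and compound 3 have the same atoms and bonds, and the step of a number 33 percentage points higher from compound 1 to compound 3 (beyond the scatter) is large; the only difference between them is the fact that one of compounds 1 and 3 is drawn with a defined configuration and the other without, at the place where they differ.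

Compound 4 `C[C@H](NC(=O)[C@H](CCCNC(=N)N)NC(=O)c1ccc(CN(Cc2ccncc2)C(=O)c2ccc(F)cc2)cc1)c1cccc2ccccc12` is the next member and differs from compound 3 by pyridin-4-yl in place of pyridin-2-yl on a saturated chain carbon bound to an amide-type nitrogen. For the measured compounds named here, none of the measured steps covers this change on its own. Compound 2 also carries pyridin-4-yl, but it differs from compound 4 in a second place as well, so its number against compound 3 cannot be read as the effect of the ring change alone. Going by the values given here, with no measured step bearing directly on it, the expectation is a step of modest size and uncertain direction, a number 8 percentage points lower from compound 3 to compound 4 (within the scatter), possibly not beyond the scatter. Compound 4 is therefore estimated at 28% in this assay, with a range from 8% to 50%.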

Compound 4, a percentage reported as inhibition, at one concentration (the size of the read-out at that concentration, not a potency): 13%
Compound 4: the middle estimate sits 15 percentage points above what was measured; low and high end bracket the measured number.
By their numbers in this assay, from the lowest: compounds 1, 4 and 2 (each within the scatter of the next, the first and the last beyond it); then compound 3.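

Pyridin-4-yl in place of pyridin-2-yl on a saturated chain carbon bound to an amide-type nitrogen gives a number 23 percentage points lower from compound 3 to compound 4 (beyond the scatter) in this assay and so shows that this place responds to the choice of pyridine isomer, even though both groups have the same heavy atoms, donor count and acceptor count. Among the compounds shown here, with pyridin-4-yl in the molecule, (4-fluorophenyl)carbonyl in place of 4-fluorobenzyl on an amine nitrogen gives a number 3 percentage points lower from compound 2 to compound 4 (within the scatter) and so does not separate these two forms, a comparison the earlier compounds could not make in a single step. Nothing on hand bears on the cause of the step between the two pyridine isomers.

Going by these compounds, it remains open whether 4-fluorobenzyl and (4-fluorophenyl)carbonyl also stay within the scatter of each other when pyridin-2-yl is the ring on the chain carbon. The compounds shown also leave open how pyridin-3-yl or a plain phenyl ring would read at this place, and thus whether the pyridin-2-yl form stands apart from rings beyond the two compared here.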